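A few compounds are considered here, and "the series" means these few. Any claim that something is new, unique, unknown or untested is made for them only; others in the source may bear on it.

Measured in a functional assay on DU-145 cells (Homo sapiens) for inhibition; a higher number here means a weaker inhibitor, a lower number a stronger inhibitor:
- compound 1 `Oc1cccc(-c2cc(-c3ccc(F)cc3)cc(-c3ccccc3O)n2)c1`: > 50000 nM; this is a limit of the assay, not a number
- compound 2 `Oc1ccc(-c2cc(-c3ccc(F)cc3)cc(-c3cccc(O)c3)n2)cc1`: 15200 nM
- compound 3 `Oc1ccc(-c2cc(-c3ccc(F)cc3)cc(-c3ccc(O)cc3)n2)cc1`: 6030 nM

Compound 2 carries the higher of the two actual numbers, and compound 3 lies nearest to it. Compound 1 gives only a limit.

Compound 4 `Oc1ccc(-c2cc(-c3ccccc3C(F)(F)F)cc(-c3cccc(O)c3)n2)cc1` keeps both hydroxyphenyl groups of compound 2 and changes the group opposite the ring nitrogen: 2-(trifluoromethyl)phenyl in place of 4-fluorophenyl on an aromatic carbon.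

Two measured steps exist, an at least 3.2-fold lower number from compound 1 to compound 2 (0.51 log units; beyond the scatter) and a 2.5-fold lower number from compound 2 to compound 3 (0.40 log units; beyond the scatter). Both alter only a hydroxyphenyl group, and neither touches the 4-fluorophenyl group. They therefore serve only as a rough gauge of how far one change can move the number in this assay, and they give no direction for this replacement.

No step beyond the scatter is expected, though a modest move either way would not surprise. The estimated step is a 1.2-fold lower number from compound 2 to compound 4 (0.07 log units; within the scatter). For compound 4 the expected value is 13000 nM, with an estimated range of 4500 nM to 40000 nM.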

Compound 4, half-maximal inhibitory concentration: 2750 nM
Compound 4: middle estimate off by 4.7-fold (0.67 log units), on the high side; the measured number lies below the stated range.
By their numbers in this assay, from the lowest: compound 4; then compound 3; then compound 2. At a limit, above all of these: compound 1.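

In this assay, the position opposite the ring nitrogen responds to the choice of aryl group: 2-(trifluoromethyl)phenyl in place of 4-fluorophenyl gives a 5.5-fold lower number from compound 2 to compound 4 (0.74 log units; beyond the scatter). Within the data shown here, the earlier steps altered only hydroxyphenyl groups, so this is the first evidence that the number can also be moved from this position, with both hydroxyphenyl groups of compound 2 left unchanged. Nothing shown gives a cause for this step.

The change replaces the fluorine with trifluoromethyl and also alters where the substituent sits on the phenyl ring, and the compounds shown do not separate these two differences. Also open, from the compounds shown here alone, are how an unsubstituted phenyl, a methoxy group or an amine at this position would read, and whether the step carries over to the two 4-hydroxyphenyl groups of compound 3.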